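Replacing 4-bromophenyl with 2-methoxyphenyl

This account rests on a few compounds, and the source may have more. Where it says the series, first, only, none or still open, it means among the compounds named here.

Compound 1 `COc1ccc(Nc2nc(N)c(C(=O)c3ccc(Cl)cc3)s2)cc1` and compound 2 `COc1ccc(Nc2nc(N)c(C(=O)c3ccc(Br)cc3)s2)cc1` share one core and differ only in a halogen. In a functional assay on HeLa cells (Homo sapiens) for antiproliferative activity, read by cell counting, with a stated time of 2 days (on this read-out lower numbers stand for stronger inhibition and higher numbers for weaker inhibition), compound 1 gives 83 nM and compound 2 gives 79 nM. For the measured compounds named here, the only measured step, a 1.1-fold lower number from compound 1 to compound 2 (0.02 log units; within the scatter), lies within the scatter, so compound 2 stands level with compound 1.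

Compound 3 `COc1ccc(Nc2nc(N)c(C(=O)c3ccccc3OC)s2)cc1` keeps the core but carries 2-methoxyphenyl in place of 4-bromophenyl on a carbonyl carbon. The measured step only exchanged bromo for chloro, so it gives little guidance here, where the halogen is lost altogether. Going by the values given here, no measurement yet tests such a loss, and the direction in this assay remains uncertain. A step of a 2.0-fold higher number from compound 2 to compound 3 (0.31 log units; beyond the scatter) is expected, a cautious guess toward weaker inhibition rather than a measured trend. For compound 3 the estimated value is 160 nM, with an expected range of 35 nM to 800 nM.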

Compound 3, half-maximal inhibitory concentration: 17 nM
Estimate against measurement, compound 3: 9.4-fold (0.97 log units) above; the measured number lies below the stated range.
By their numbers in this assay, from the lowest: compound 3; then compounds 2 and 1 (each within the scatter of the next).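

For the compounds shown here, the halogen exchange between the earlier compounds left the number level, but the group on this carbonyl carbon clearly matters: in this assay 2-methoxyphenyl in place of 4-bromophenyl gives a 4.6-fold lower number from compound 2 to compound 3 (0.67 log units; beyond the scatter) and in place of 4-chlorophenyl gives a 4.9-fold lower number from compound 1 to compound 3 (0.69 log units; beyond the scatter) in the same direction. Among these three compounds, then, a halogen on this ring is not needed for strong inhibition, and the one compound without it, which carries a hydrogen-bond acceptor on this group, gives the lowest number. Nothing available explains this gain.

On these data alone, the change removes the halogen and adds the methoxy group in a single step, so the share of each stays open. The compounds shown also leave open how an ethoxy group or an amine on this ring would compare.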